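The source may report more compounds than this note shows. Statements on the series, on what has been measured and on what is new or still open speak of the compounds shown alone.

Compounds measured so far:
- compound 1, `Cn1c(-c2ccc(F)cc2)nc2c(NC3CCCC3)ncnc21` — in a functional assay on CHO cells for antagonist activity at adenosine receptor A2b (Homo sapiens), read by 33P incorporation, with a stated time of 20 min (a lower number here means a stronger inhibitor, a higher number a weaker inhibitor), compound 1 reaches only a limit of the assay, > 30000 nM.
- compound 2, `Cn1c(-c2ccc(O)cc2)nc2c(NC3CCCC3)ncnc21` — in this assay compound 2 gives 17800 nM.

Among the compounds with values here, compound 2 thus holds the only actual number in this assay; compound 1 sits at a limit, as the limit of > 30000 nM in this assay, at which 1 of the 2 values shown sits, records, so the step of an at least 1.6-fold lower number from compound 1 to compound 2 (0.22 log units; that floor lies within the scatter) is a floor rather than a measured size.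

Compound 3, `Cn1c(-c2cccnc2)nc2c(NC3CCCC3)ncnc21`, differs from compound 2 by pyridin-3-yl in place of 4-hydroxyphenyl on an aromatic carbon. Within the data shown here, the only step that touches this position is the one from compound 1 to compound 2, and its floor lies within the scatter; it tells nothing about exchanging the whole ring for pyridin-3-yl. No step beyond the scatter is therefore expected in this assay, at most a drift toward a higher number, as the hydroxy of compound 2 leaves. Compound 3 is expected to give 25000 nM (range 8000 nM to 70000 nM). That implies an expected step of a 1.4-fold higher number from compound 2 to compound 3 (0.15 log units; within the scatter).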

Compound 3, inhibition constant: > 30000 nM
Compound 3: no number, only a limit (the forecaster's own chance of this, stated with the estimate: 40%); middle value at least 1.2-fold (0.07 log units) away from the limit.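

Pyridin-3-yl in place of 4-hydroxyphenyl gives an at least 1.6-fold higher number from compound 2 to compound 3 (0.22 log units; that floor lies within the scatter), so a second change at this aromatic carbon also yields only a floor, and no effect of exchanging the whole ring can be sized beyond the scatter. The step between compound 1 and compound 3 cannot be read, as both values are limits. Of the three groups shown at this position in this assay, only 4-hydroxyphenyl gives an actual number, while 4-fluorophenyl and pyridin-3-yl both stop at a limit of the assay: the limit of > 30000 nM in this assay, at which 2 of the 3 values shown sit.

Still open, as far as these compounds go, is what a methoxy or an amino group in place of the hydroxy on the phenyl ring would give in this assay. Also open is how far compound 1 and compound 3 lie from compound 2, as their true values are not shown.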